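The compounds below may be only part of what the source reports. "The series", "measured", "known", "first", "only" and "open" are said of these compounds alone.

Compound 1 `CC(C)OC1=C(C(=O)c2ccccc2)C(c2ccc(Br)cc2)N(CCCn2ccnc2)C1=O`: 18900 nM
Compound 2 `CCCCOC1=C(C(=O)c2ccccc2)C(c2ccc(Br)cc2)N(CCCn2ccnc2)C1=O`: 17100 nM
Compound 3 `O=C(C1=C(Nc2ccccc2)C(=O)N(CCCn2ccnc2)C1c1ccc(Br)cc1)c1ccccc1`: 21200 nM

Three compounds share a core and were tested in a functional assay on NCI-H1299 cells (Homo sapiens) for antiproliferative activity, read by MTT assay, with a stated time of 72 h; a higher number here means a weaker inhibitor, a lower number a stronger inhibitor. Compound 2 holds the smallest of the three numbers, yet it stands apart from neither neighbour: the change from compound 1 to compound 2 gives a 1.1-fold lower number from compound 1 to compound 2 (0.04 log units; within the scatter), and the change from compound 2 to compound 3 gives a 1.2-fold higher number from compound 2 to compound 3 (0.09 log units; within the scatter). Compound 1 and compound 3 likewise sit close together, with a 1.1-fold higher number from compound 1 to compound 3 (0.05 log units; within the scatter).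

Compound 4 `Cc1ccc(NC2=C(C(=O)c3ccccc3)C(c3ccc(Br)cc3)N(CCCn3ccnc3)C2=O)cc1` has not yet been measured in this assay. It differs from compound 2 in one place: (4-methylphenyl)amino in place of butoxy on a double-bonded ring carbon. Among the compounds with values here, the step that bears most directly on it is the one from compound 2 to compound 3, where an anilino group replaced the butoxy group and the number moved only within the scatter; the step from compound 1 to compound 3 tells the same. Within the data shown here, compound 4 carries a methyl on the anilino ring beyond what compound 3 has, and no measured pair speaks to that methyl, so no step beyond the scatter is expected in this assay in either direction.

Compound 4 is therefore expected to give 20000 nM, in a range from 10000 nM to 40000 nM. This estimate amounts to an expected 1.2-fold higher number from compound 2 to compound 4 (0.07 log units; within the scatter).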

Compound 4, half-maximal inhibitory concentration: 25800 nM
Compound 4: the middle estimate sits 1.3-fold (0.11 log units) below what was measured; the range from low to high includes it.
By their numbers in this assay, from the lowest: compounds 2, 1, 3 and 4 (each within the scatter of the next).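

In this assay, (4-methylphenyl)amino on the double-bonded ring carbon stays within the scatter whether it replaces butoxy (a 1.5-fold higher number from compound 2 to compound 4 (0.18 log units; within the scatter)) or isopropoxy (a 1.4-fold higher number from compound 1 to compound 4 (0.14 log units; within the scatter)), so this position has now taken a substituted aromatic ring on its amino group with no clear shift in the number. Within the data shown here, the methyl, about which the earlier compounds said nothing, can now be read directly, and methyl in place of hydrogen on an aromatic carbon of the anilino ring also stays within the scatter (a 1.2-fold higher number from compound 3 to compound 4 (0.09 log units; within the scatter)). No measurement at hand offers an explanation for how closely these numbers sit.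

Since all four compounds lie within the scatter of one another, the compounds shown leave open whether any group on this ring carbon can move the number beyond the scatter, and a morpholine, a carboxylic acid or a much longer alkoxy chain there would test that. They also leave open what a chlorine or a methoxy in place of the methyl would do, and how much the benzoyl, 4-bromophenyl and 3-(1H-imidazol-1-yl)propyl groups, the same throughout, contribute.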